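Urea Series: Adding a Second Ethyl Group

This account rests on a few compounds, and the source may have more. Where it says the series, first, only, none or still open, it means among the compounds named here.

Measured so far:
compound 1 `CCc1ccccc1NC(=O)N[C@@H](C)c1ccccc1`: 100%
compound 2 `C[C@H](NC(=O)Nc1ccccc1F)c1ccccc1`: 98%
compound 3 `C[C@H](NC(=O)Nc1ccccc1Cl)c1ccccc1`: 99%

In an ADME assay on the whole organism with Oryza sativa as the target, tested at 0.1 uM (a lower number here means a stronger effect, a higher number a weaker effect of the compound at the concentration tested), compound 1 gives 100%. This is the highest of the three numbers, yet a number 2 percentage points lower from compound 1 to compound 2 (within the scatter) and a number 1 percentage points lower from compound 1 to compound 3 (within the scatter) both lie within the scatter, so the three compounds cannot be ordered. Compound 4 `CCc1cccc(CC)c1NC(=O)N[C@@H](C)c1ccccc1` differs from compound 1 by ethyl in place of hydrogen on an aromatic carbon. Among the measured compounds shown here, none of the measured steps adds a group; they only exchange the ethyl group for fluoro or chloro, and a number 1 percentage points higher from compound 2 to compound 3 (within the scatter) likewise stays within the scatter. These steps give no ground for a change beyond the scatter, and the step expected for compound 4 is a number 3 percentage points lower from compound 1 to compound 4 (within the scatter). Compound 4 is accordingly estimated at 97%, with a range from 85% to 100%.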

Compound 4, a percentage reported as activity, at one concentration (the size of the read-out at that concentration, not a potency): 101%
The estimate for compound 4 lay 4 percentage points below the measured number; the measured number lies above the stated range.
By their numbers in this assay, from the lowest: compounds 2, 3, 1 and 4 (each within the scatter of the next).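

Earlier steps only exchanged the ethyl group for fluoro or chloro, whereas this step adds a group: ethyl in place of hydrogen on an aromatic carbon, ortho to a large group and meta to an ethyl group. In this assay this addition gives a number 1 percentage points higher from compound 1 to compound 4 (within the scatter) and so no change beyond the scatter at this position. No measured evidence bears on this result. Going by these compounds, whether an amine, a carboxylic acid or a longer chain at this position would move the number beyond the scatter remains open.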